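The source may hold more compounds than are shown below. What is called first, only, known or untested is meant among the compounds shown, and "the series" means these compounds.

Measured so far:
Compound 1 `NS(=O)(=O)CC(=O)NCCSc1nonc1/C(=N/O)Nc1ccc(F)c(C(F)F)c1` — in an ADME assay on isolated protein for pharmacokinetics, with UDP-glucuronosyltransferase 1A9 (Homo sapiens) as the target, read by LC-MS, with a stated time of 60 min, at 37 degrees C, tested at 1 uM, in the presence of a further agent that is not named here (on this read-out higher numbers stand for a longer-lived compound and lower numbers for a shorter-lived compound), compound 1 reaches only a limit of the assay, > 3 h.
Compound 2 `NS(=O)(=O)CC(=O)NCCSc1nonc1/C(=N/O)Nc1ccc(F)c(Br)c1` — in this assay compound 2 gives 0.758 h.

Going by the values given here, compound 2 carries the only numerical value in this assay within the pair; the other value, that of compound 1, is a limit (the limit of > 3 h in this assay, at which 1 of the 2 values shown sits). Among the compounds with values here, the single measured step, an at least 3.9-fold lower number from compound 1 to compound 2 (0.59 log units; beyond the scatter), concerns the substituent on the aromatic ring and leaves the side chain untouched, so it gives no direct guide to a change made on the chain.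

Compound 3 `CS(=O)(=O)NCCSc1nonc1/C(=N/O)Nc1ccc(F)c(Br)c1` differs from compound 2 at that other end: methylsulfonyl in place of (sulfamoylmethyl)carbonyl on an amine nitrogen. Within the data shown here, no measured step in this assay covers this part of the molecule, and the one step that exists points in neither direction for it. With nothing to build on beyond the value of compound 2 in this assay, the step is expected to stay within the usual scatter, a 1.1-fold higher number from compound 2 to compound 3 (0.02 log units; within the scatter), with the range kept wide. Compound 3 is therefore estimated at 0.8 h, with a range from 0.3 h to 2.5 h.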

Compound 3, half-life: 0.357 h
Beside the measured number, compound 3's estimate is 2.2-fold (0.35 log units) above it; measured number inside the range.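

Half-life in this assay responds to the group on the amine nitrogen as well as to the aromatic substituent: with the bromo substituent held constant, methylsulfonyl in place of (sulfamoylmethyl)carbonyl gives a 2.1-fold lower number from compound 2 to compound 3 (0.33 log units; beyond the scatter). Going by these compounds alone, this is the first measured step at this end of the molecule, and it shows that the (sulfamoylmethyl)carbonyl group is the longer-lived of the two options on this amine nitrogen in the bromo series, a comparison that rests on this one pair alone. No measurement shown gives a reason for this step.

The exchange replaces the whole group at once, so the compounds shown leave open whether the difference follows the carbonyl, the terminal sulfamoyl or the overall size of the group, a question that an acetyl group or a free amine on the same nitrogen would help to separate. Also open, as far as these compounds go, is whether the step keeps its direction and size with difluoromethyl in place of bromo on the aromatic carbon.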